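The compounds below may be only part of what the source reports. "The series", "measured", "known", "first", "only" and "open" are said of these compounds alone.

In a functional assay on NCI-H1975 cells (Homo sapiens) for antiproliferative activity, read by MTT assay, with a stated time of 72 h (on this read-out lower numbers stand for stronger inhibition and higher numbers for weaker inhibition), compound 3 `Cc1cccc(Nc2ncnc3ccc(NC(=S)Nc4ccc(S(N)(=O)=O)cc4)cc23)c1` gives 35400 nM and sits second highest of the three numbers measured. Compound 2 `NS(=O)(=O)c1ccc(NC(=S)Nc2ccc3ncnc(Nc4cccc(Cl)c4)c3c2)cc1` gives 39800 nM, the step being a 1.1-fold lower number from compound 2 to compound 3 (0.05 log units; within the scatter). Compound 1 `NS(=O)(=O)c1ccc(NC(=S)Nc2ccc3ncnc(Nc4ccc(C(F)(F)F)cc4)c3c2)cc1` gives 17100 nM; the steps are a 2.3-fold higher number from compound 1 to compound 2 (0.37 log units; beyond the scatter) and a 2.1-fold higher number from compound 1 to compound 3 (0.32 log units; beyond the scatter), both modest. Compound 4 `CCc1ccc(Nc2ncnc3ccc(NC(=S)Nc4ccc(S(N)(=O)=O)cc4)cc23)cc1` differs from compound 3 by 4-ethylphenyl in place of 3-methylphenyl on a nitrogen on an aromatic ring. Going by the values given here, no measured step exchanges exactly these two groups; the steps that do change the group on this nitrogen were all modest, so in this assay no more than a modest step is expected, in either direction, and a result within the scatter of compound 3 is the likeliest outcome. Compound 4 is estimated at 30000 nM, with a range of 12000 nM to 75000 nM. This corresponds to an expected step of a 1.2-fold lower number from compound 3 to compound 4 (0.07 log units; within the scatter).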

Compound 4, half-maximal inhibitory concentration: 38700 nM
Compound 4: the middle estimate sits 1.3-fold (0.11 log units) below what was measured, and the stated range covers the measured number.
By their numbers in this assay, from the lowest: compound 1; then compounds 3, 4 and 2 (each within the scatter of the next).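

In this assay, 4-ethylphenyl on this nitrogen stays within the scatter of 3-methylphenyl (a 1.1-fold higher number from compound 3 to compound 4 (0.04 log units; within the scatter)) and of 3-chlorophenyl (a 1.0-fold lower number from compound 2 to compound 4 (0.01 log units; within the scatter)), so a group in the 4-place does not by itself give a lower number. Ethyl in place of trifluoromethyl gives the only step here beyond the scatter (a 2.3-fold higher number from compound 1 to compound 4 (0.35 log units; beyond the scatter)), which ties the lower number of compound 1 to trifluoromethyl rather than to its place on the ring. No available data explain this difference.

Going by these compounds, whether a 4-methoxyphenyl, 4-chlorophenyl or 4-cyanophenyl group would side with trifluoromethyl or with ethyl stays open.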